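Chloro on the benzimidazol-2-yl group: expected growth inhibition

The source may report more compounds than this note shows. Statements on the series, on what has been measured and on what is new or still open speak of the compounds shown alone.

Measured so far:
compound 1 `CCn1cc(-c2nc3ccccc3[nH]2)c(=O)c2cc(F)c(N3CCNCC3)cc21` — > 10000 nM
compound 2 `CCn1cc(-c2nc3ccccc3[nH]2)c(=O)c2cc(F)c(N3CCNCC3)nc21` — > 10000 nM

In a functional assay on PC-3 cells (Homo sapiens) for cytotoxicity, read by sulforhodamine B assay, with a stated time of 48 h (on this read-out lower numbers stand for stronger inhibition of growth and higher numbers for weaker inhibition of growth), compound 1 returns only a limit, > 10000 nM, and no number. Compound 2 likewise gives a limit, > 10000 nM. Compound 1 thus sits at the limit of > 10000 nM in this assay, at which 2 of the 2 values shown sit, so no ranking against compound 2 is possible. Compound 3 `CCn1cc(-c2nc3ccc(Cl)cc3[nH]2)c(=O)c2cc(F)c(N3CCNCC3)cc21` differs from compound 1 by chloro in place of hydrogen on an aromatic carbon. Within the data shown here, no step between measured compounds exists here; the expected step from compound 1 to compound 3 is a step that the limit leaves unreadable from compound 1 to compound 3, none beyond the scatter. Compound 3 is expected at 15000 nM, ranging from 3000 nM to 60000 nM.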

Compound 3, concentration for 50% growth inhibition: 3300 nM
Compound 3: middle estimate off by 4.5-fold (0.66 log units), on the high side, and the stated range covers the measured number.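

In this assay, going from 1H-benzimidazol-2-yl to 6-chloro-1H-benzimidazol-2-yl gives an at least 3.0-fold lower number from compound 1 to compound 3 (0.48 log units; beyond the scatter), so this aromatic carbon is a place where a single substitution yields a readable number. The earlier compounds shown here showed no such response. The true size of the step remains unknown because compound 1 carries only a limit: the limit of > 10000 nM in this assay, at which 2 of the 3 values shown sit.

On these data alone, whether this is specific to chloro stays open; a fluoro, a methoxy or an amine at the same carbon would address that. Also open, as far as these compounds go, is whether chloro has the same effect on the core of compound 2.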